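Lengthening the Amide Chain, One Carbon at a Time

The source may hold more compounds than are shown below. What is called first, only, known or untested is meant among the compounds shown, and "the series" means these compounds.

Three measured compounds share one core and differ only in the chain on the amide-type nitrogen. Compound 1 `CNC(=O)c1ccc(S(N)(=O)=O)cc1` gives -0.31 in a physicochemical assay for lipophilicity; a lower number here means a more polar compound, a higher number a more lipophilic compound. Compound 2 `CCNC(=O)c1ccc(S(N)(=O)=O)cc1` gives 0.03 in this assay, and compound 3 `CCCCCCNC(=O)c1ccc(S(N)(=O)=O)cc1` gives 2.05 in this assay. The steps between them are a number 0.34 log units higher from compound 1 to compound 2 (beyond the scatter), a number 2.36 log units higher from compound 1 to compound 3 (beyond the scatter) and a number 2.02 log units higher from compound 2 to compound 3 (beyond the scatter). Compound 4 `CCCCCCCNC(=O)c1ccc(S(N)(=O)=O)cc1` has not yet been measured in this assay.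

The change from compound 3 to compound 4 is methyl in place of hydrogen on a saturated chain carbon, six bonds along the chain from an amide-type nitrogen. The same kind of change is seen from compound 1 to compound 2, (methyl in place of hydrogen on a saturated chain carbon bound to an amide-type nitrogen), where the step was a number 0.34 log units higher from compound 1 to compound 2 (beyond the scatter); the two places differ, one being bound to an amide-type nitrogen and the other six bonds along the chain from an amide-type nitrogen. The cores of compound 1 and compound 3 differ by pentyl in place of hydrogen on a saturated chain carbon bound to an amide-type nitrogen.

The expected step is a number 0.50 log units higher from compound 3 to compound 4 (beyond the scatter) in this assay, somewhat larger than the earlier one, because a number 2.02 log units higher from compound 2 to compound 3 (beyond the scatter) spread over a butyl points to about that amount for each added carbon. Compound 4 is estimated at 2.55, between 2.25 and 2.85.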

Compound 4, partition coefficient: 2.57
Beside the measured number, compound 4's estimate is 0.02 log units below it; low and high end bracket the measured number.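

In this assay the exchange of hydrogen for methyl gave a number 0.52 log units higher from compound 3 to compound 4 (beyond the scatter) and on the core of compound 1 the same kind of change gave a number 0.34 log units higher from compound 1 to compound 2 (beyond the scatter), so the step ran in the same direction on both cores and lay beyond the scatter each time. The larger changes run the same way, with pentyl giving a number 2.54 log units higher from compound 2 to compound 4 (beyond the scatter) and hexyl giving a number 2.88 log units higher from compound 1 to compound 4 (beyond the scatter). Among these compounds, this shows only that methyl raised the number on these two cores, at two different places, one bound to an amide-type nitrogen and one six bonds along the chain from it; it does not show that the step would keep its size on any other core, and no measurement offered here accounts for the steps.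

The compounds shown leave open how a longer chain would read in this assay and whether the steps would continue in this direction. They also leave open what an amine or a carboxylic acid in place of the methyl would do to the number.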